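The source may report more compounds than this note shows. Statements on the series, on what has been measured and on what is new or still open speak of the compounds shown alone.

For the measured compounds named here, compound 3 `CC(C)OC(=O)N1CCC(n2ncc3cc(-c4ccc(C(N)=O)cc4F)ncc32)CC1` gives 97 nM in a functional assay on HEK293 cells for agonist activity at Glucose-dependent insulinotropic receptor (Homo sapiens), read by cAMP accumulation, with a stated time of 30 min (on this read-out higher numbers stand for an effect only at larger amounts of compound and lower numbers for an effect already at smaller amounts), the second highest of the three numbers measured so far. Compound 2 `CC(C)OC(=O)N1CCC(n2ncc3cc(-c4ccc(S(C)(=O)=O)nc4)ncc32)CC1` gives 197 nM, and the step between them is a 2.0-fold lower number from compound 2 to compound 3 (0.31 log units; beyond the scatter); compound 1 `CC(C)OC(=O)N1CCC(n2ncc3cc(-c4ccc(S(C)(=O)=O)cc4)ncc32)CC1` gives 42 nM, and the step between them is a 2.3-fold higher number from compound 1 to compound 3 (0.36 log units; beyond the scatter). Compound 4 `CC(C)OC(=O)N1CCC(n2ncc3cc(-c4cc(F)c(C(N)=O)cc4F)ncc32)CC1` differs from compound 3 by fluoro in place of hydrogen on an aromatic carbon. Going by the values given here, no measured step is a simple exchange of hydrogen for fluoro; the only step that brings in a fluoro, a 2.3-fold higher number from compound 1 to compound 3 (0.36 log units; beyond the scatter), changes the carbamoyl group at the same time, so it offers no clean guidance. The expected step is therefore no change at the digits printed from compound 3 to compound 4 (within the scatter), not beyond the scatter. Compound 4 is estimated at 97 nM, between 45 nM and 220 nM.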

Compound 4, half-maximal effective concentration: 52 nM
Beside the measured number, compound 4's estimate is 1.9-fold (0.27 log units) above it; the measured number falls inside the stated range.
By their numbers in this assay, from the lowest: compounds 1, 4 and 3 (each within the scatter of the next, the first and the last beyond it); then compound 2.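

Fluoro on the aromatic carbon ortho to the carbamoyl group and para to the fluoro group gives in this assay the first clean exchange of hydrogen for fluoro among these compounds, read as a 1.9-fold lower number from compound 3 to compound 4 (0.27 log units; within the scatter) and so no change that can be told from scatter. This position therefore accepts the added fluoro without a step beyond the scatter. No evidence is available that bears on this result.

On these data alone, whether a chloro or a methoxy would be accepted at this position remains open. Also open is what the fluoro group already present in compound 3 contributes, since no compound shown carries the carbamoyl group without it.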